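The compounds below may be only part of what the source reports. "The series", "measured", "known", "first", "only" and "open" are said of these compounds alone.

Notes on the series. The three measured compounds share one core and differ only in the aryl group carried on the five-membered ring. Compound 1 `Cc1oc(-c2ccccc2Cl)nc1CN1CCC(C(=O)NCCCN2C[C@H](C)C[C@H](C)C2)CC1` gives in a physicochemical assay for solubility, in phosphate buffer, measured as kinetic solubility, at pH 7.4 (on this read-out lower numbers stand for lower solubility and higher numbers for higher solubility), a value that is a limit of the assay, > 72 ug/mL. Compound 2 `Cc1oc(-c2c(Cl)cccc2Cl)nc1CN1CCC(C(=O)NCCCN2C[C@H](C)C[C@H](C)C2)CC1` likewise gives in this assay a limit, > 77 ug/mL. Compound 3 `COc1cccc(Cl)c1-c1nc(CN2CCC(C(=O)NCCCN3C[C@H](C)C[C@H](C)C3)CC2)c(C)o1` also gives in this assay a limit, > 76 ug/mL. Compound 3 therefore stands at a limit, and the two other values shown are limits as well; the three lines (the limit of > 72 ug/mL in this assay, at which 1 of the 3 values shown sits), the limit of > 76 ug/mL in this assay, at which 1 of the 3 values shown sits, and the limit of > 77 ug/mL in this assay, at which 1 of the 3 values shown sits, each hold one value. As a result the steps a step that the two limits leave unreadable from compound 1 to compound 2, a step that the two limits leave unreadable from compound 1 to compound 3 and a step that the two limits leave unreadable from compound 2 to compound 3 cannot be read in size or direction.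

Compound 4 `Cc1cc(C)cc(-c2nc(CN3CCC(C(=O)NCCCN4C[C@H](C)C[C@H](C)C4)CC3)c(C)o2)c1` is the next member, with the change (3,5-dimethylphenyl in place of 2-chloro-6-methoxyphenyl on an aromatic carbon). Within the data shown here, the steps that bear on it are the aryl-ring changes from compound 1 to compound 3 and from compound 2 to compound 3, both unreadable because of the limit of > 76 ug/mL in this assay, at which 1 of the 3 values shown sits. No step beyond the scatter can therefore be predicted for this assay, and compound 4 is expected to sit near the limits already seen, with an expected step of an at least 1.0-fold lower number from compound 3 to compound 4 (0.03 log units; that floor lies within the scatter). The estimate for compound 4 in this assay is 70 ug/mL, within 30 ug/mL to 110 ug/mL.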

Compound 4, solubility: > 71 ug/mL
Compound 4: no number, only a limit (the forecaster's own chance of this, stated with the estimate: 60%); middle value at least 1.0-fold (0.00 log units) from the limit.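

In this assay compound 4 gives > 71 ug/mL, which is a limit of the assay. Among these compounds, no step from compound 1, compound 2 or compound 3 to compound 4 can be read, in either size or direction. The compounds shown leave open whether these four compounds differ at all in this assay, and by how much.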